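Adding an Amino Group to a Fused Ring Core

A few compounds are considered here, and "the series" means these few. Any claim that something is new, unique, unknown or untested is made for them only; others in the source may bear on it.

Of the compounds shown here, three have been tested so far in a functional assay on the whole organism (Leg) with Mus musculus as the target, at a dose of 0.96 mg/kg by the subcutaneous route; on this read-out higher numbers stand for an effect only at larger amounts of compound and lower numbers for an effect already at smaller amounts. Compound 1 `Cc1nnc(NC(N)=O)cc1Cc1ccccc1` gives 28 mg/kg. Compound 2 `Cc1nn2cnnc2cc1Cc1ccccc1` gives 85 mg/kg. Compound 3 `Cc1nn2cnnc2cc1Cc1c(Cl)cccc1Cl` gives 39.5 mg/kg, which is the second highest of the three numbers; its nearest neighbour is compound 1, whose number differs by an amount within the usual scatter, while compound 2 sits furthest away, with a higher number beyond the scatter.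

Compound 4 `Cc1nn2c(N)nnc2cc1Cc1c(Cl)cccc1Cl` has not yet been measured. It differs from compound 3 in one place: amino in place of hydrogen on an aromatic carbon. Going by the values given here, no pair of measured compounds shows this same change, so there is no direct step to lean on. Compound 1 carries a nitrogen-bearing group on its own core, but its core is not the same as that of compound 3, so its number gives only loose guidance.

With nothing closer to go on, the step from compound 3 to compound 4 is expected to be small, a 1.2-fold lower number from compound 3 to compound 4 (0.09 log units; within the scatter), with no clear direction beyond the scatter. Compound 4 is therefore estimated at 32 mg/kg in this assay, within a range of 12 mg/kg to 80 mg/kg.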

Compound 4, dose for half-maximal effect: 34.5 mg/kg
For compound 4 the middle estimate is 1.1-fold (0.03 log units) below the measured one; the measured number falls inside the stated range.
By their numbers in this assay, from the lowest: compounds 1, 4 and 3 (each within the scatter of the next); then compound 2.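

Putting amino in place of hydrogen on an aromatic carbon, between two ring nitrogen atoms of the five-membered aromatic ring, gives a 1.1-fold lower number from compound 3 to compound 4 (0.06 log units; within the scatter) in this assay. Going by these compounds alone, this is the first direct reading of any change at this position, and it shows that here the new amino group leaves the number indistinguishable from that of the parent compound. Nothing measured here accounts for this result.

A single step on one core cannot show whether the same change on compound 2 would also stay within the scatter. It also leaves open how other groups on this carbon, such as a methylamino group, a carboxylic acid or a longer chain, would fare in this read-out.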